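The compounds below may be only part of what the source reports. "The series", "measured", "known", "first", "only" and "open" are said of these compounds alone.

Compound 1 `Fc1cccc(F)c1Cn1c(-c2c(F)cccc2F)nc2ccncc21`: 99000 nM
Compound 2 `Fc1cccc(Cn2ccc3nc(-c4ccccc4)nc-3c2)c1`: > 100000 nM (a limit of the assay)
Compound 3 `O=C(O)c1ccc(Cn2ccc3nc(-c4ccccc4)nc-3c2)cc1`: > 100000 nM (a limit of the assay)

In an ADME assay on MDBK cells (Bos taurus) for cytotoxicity (a higher number here means that more compound is tolerated, a lower number that less compound is tolerated), compound 1 gives 99000 nM. Compound 2 gives only > 100000 nM, which is a limit of the assay and not a number. Compound 3 likewise stops at > 100000 nM, again a limit. For the measured compounds named here, compound 2 therefore stands at the limit of > 100000 nM in this assay, at which 2 of the 3 values shown sit, and no measured step starts from it.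

Compound 4 `c1ccc(-c2nc3ccn(Cc4cccnc4)cc-3n2)cc1` differs from compound 2 in one place: pyridin-3-yl in place of 3-fluorophenyl on a saturated chain carbon bound to an aromatic nitrogen. Going by the values given here, no pair of measured compounds covers this change. Given that compound 2 sits at the limit of > 100000 nM in this assay, at which 2 of the 3 values shown sit, the step of a number no higher from compound 2 to compound 4 (the limit leaves the size open) is expected to be none beyond the scatter. Compound 4 is accordingly estimated at 100000 nM, within 50000 nM to 200000 nM, most likely reported again as a limit.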

Compound 4, half-maximal cytotoxic concentration: > 100000 nM
Compound 4: no number, only a limit; the forecaster's own chance of this, stated with the estimate: 65%; the middle value lies on the limit itself.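

Compound 4 stops at > 100000 nM which is a limit of the assay and not a number, so no step from compound 2 to compound 4 can be read: the limit of > 100000 nM in this assay, at which 3 of the 4 values shown sit.

The compounds shown leave open whether pyridin-3-yl and 3-fluorophenyl differ at all in tolerated concentration.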